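The compounds below may be only part of what the source reports. "The series", "measured", "known", "first", "only" and "open" are said of these compounds alone.

Compound 1 `Cc1cccc(NC(=O)c2ccccc2)n1` — 35000 nM
Compound 2 `Cc1cccc(NC(=O)c2cccc(OS(C)(=O)=O)c2)n1` — 83600 nM
Compound 3 `Cc1cccc(NC(=O)c2cccc(C#N)c2)n1` — 330 nM

In an assay on membranes from brain for binding affinity to metabotropic glutamate receptor 5 (Rattus norvegicus) (a lower number here means a stronger inhibitor, a higher number a weaker inhibitor), compound 3 stands lowest of the three, with a 110-fold lower number from compound 1 to compound 3 (2.03 log units; beyond the scatter) and a 250-fold lower number from compound 2 to compound 3 (2.40 log units; beyond the scatter) both well beyond the scatter. Compound 4 `Cc1cccc(NC(=O)c2cccc(Oc3ccccc3)c2)n1` differs from compound 3 by phenoxy in place of cyano on an aromatic carbon. For the measured compounds named here, no measured step introduces a phenoxy group, so the relevant steps are the two at the same position: a 110-fold lower number from compound 1 to compound 3 (2.03 log units; beyond the scatter) shows how much of the affinity rests on the cyano group, and a 2.4-fold higher number from compound 1 to compound 2 (0.38 log units; beyond the scatter) shows that another oxygen-attached substituent there brought a modest rise rather than a fall. Losing the cyano is therefore expected to cost most of its gain, a large rise in this assay. Compound 4 is expected to give 20000 nM, between 3000 nM and 100000 nM, an expected step of a 61-fold higher number from compound 3 to compound 4 (1.78 log units; beyond the scatter).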

Compound 4, half-maximal inhibitory concentration: 57000 nM
Estimate against measurement, compound 4: 2.9-fold (0.45 log units) below, within the range that was stated.
By their numbers in this assay, from the lowest: compound 3; then compounds 1, 4 and 2 (each within the scatter of the next, the first and the last beyond it).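

In this assay, phenoxy in place of cyano gives a 170-fold higher number from compound 3 to compound 4 (2.24 log units; beyond the scatter), so the affinity does not survive this exchange of one group for a larger one at this position. Phenoxy in place of hydrogen gives a 1.6-fold higher number from compound 1 to compound 4 (0.21 log units; within the scatter), and phenyl in place of methylsulfonyl on the oxygen gives a 1.5-fold lower number from compound 2 to compound 4 (0.17 log units; within the scatter), both within the scatter. Among the compounds shown, only the cyano group stands clearly apart from hydrogen by a large step.

Going by these compounds, whether an amine, a carboxylic acid or a chlorine atom at this position would keep any of that gain remains open. Nothing shown here gives a measured reason for the standing of the cyano group.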